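Anilide ring substituent removal in the aryl-amino nitrile series

The source may hold more compounds than are shown below. What is called first, only, known or untested is meant among the compounds shown, and "the series" means these compounds.

Compound 2 `N#Cc1c(Nc2ccc(F)cc2)nc(SCc2cn(Cc3ccccc3Cl)nn2)nc1-c1ccccc1` gives 19900 nM in a functional assay on MCF7 cells (Homo sapiens) for inhibition, read by MTT assay, with a stated time of 72 h; on this read-out higher numbers stand for weaker inhibition and lower numbers for stronger inhibition; of the two numbers in hand, it and compound 1 sit within the scatter of each other. Compound 1 `Cc1cccc(Nc2nc(SCc3cn(Cc4ccccc4Cl)nn3)nc(-c3ccccc3)c2C#N)c1` gives 19600 nM in this assay, and the step of a 1.0-fold higher number from compound 1 to compound 2 (0.01 log units; within the scatter) shows that changing the aryl group on the ring nitrogen left the read-out essentially unmoved. Compound 3 `N#Cc1c(Nc2ccccc2)nc(SCc2cn(Cc3ccccc3Cl)nn2)nc1-c1ccccc1` differs from compound 2 by hydrogen in place of fluoro on an aromatic carbon, on an aromatic carbon of a six-membered aromatic ring of carbon only, para to a large group. Going by the values given here, the only measured step that bears on this aryl position, from compound 1 to compound 2, was within the scatter, so nothing in hand points to a shift in either direction. Compound 3 is therefore expected to stay close to compound 2, with an expected step of a 1.0-fold lower number from compound 2 to compound 3 (0.02 log units; within the scatter). The estimate for compound 3 is 19000 nM, in the range 8000 nM to 45000 nM.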

Compound 3, half-maximal inhibitory concentration: > 64000 nM
Compound 3 gave a limit, no number; the forecaster's own chance of this, stated with the estimate: 5%; middle value at least 3.3-fold (0.52 log units) from the limit.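

In this assay compound 3 stands as a limit of the assay, not a number: the limit of > 64000 nM in this assay, at which 1 of the 3 values shown sits. The unsubstituted anilino ring separates from both substituted rings, with an at least 3.2-fold higher number from compound 2 to compound 3 (0.50 log units; beyond the scatter) for hydrogen in place of fluoro and an at least 3.2-fold higher number from compound 1 to compound 3 (0.51 log units; beyond the scatter) for hydrogen in place of methyl, while a 1.0-fold higher number from compound 1 to compound 2 (0.01 log units; within the scatter) had shown no separation between the two substituted rings. Across these three compounds, the presence of a substituent on this ring therefore counts for more than the choice between fluoro and methyl, a distinction the earlier pair could not reveal.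

From the compounds shown here alone, how far compound 3 lies past its limit stays unknown, so both new steps have only a lower bound. Going by these compounds, whether an amine, a carboxylic acid or a methoxy group on this ring would read like fluoro or like hydrogen remains open.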